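Swapping an Aryl Sulfone for an Amide: Compound 4

The source may report more compounds than this note shows. Statements on the series, on what has been measured and on what is new or still open speak of the compounds shown alone.

Compound 1 `CCN(CC)S(=O)(=O)c1ccc(S(=O)(=O)N2CCC[C@@H](C(=O)N(C)C(C)C)C2)cc1` sits at a limit in a functional assay on MIA PaCa-2 cells (Homo sapiens) for inhibition, read by MTT assay, with a stated time of 3 days (on this read-out higher numbers stand for weaker inhibition and lower numbers for stronger inhibition), reading > 10000 nM.
Compound 2 `CCOC(=O)[C@H]1CCN(S(=O)(=O)c2ccc(S(=O)(=O)N(CC)CC)cc2)C1` also sits at a limit in this assay, reading > 10000 nM.
Compound 3 `CC(C)c1noc(N2CCN(C(=O)[C@@H]3CCCN(S(=O)(=O)c4ccc(S(=O)(=O)C5CCC5)cc4)C3)CC2)n1` sits at a limit in this assay too, reading > 10000 nM.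

All three measured compounds share the same fate: none of them shows a measurable number, and each reading is a limit of the assay rather than a value. Compound 3 therefore stands nowhere distinct on these numbers; it is level with compound 1 and compound 2 at the edge of what this assay reports, as the limit of > 10000 nM in this assay, at which 3 of the 3 values shown sit, records.

Compound 4 `CCN(CC)C(=O)c1ccc(S(=O)(=O)N2CCC[C@@H](C(=O)N3CCN(c4nc(C(C)C)no4)CC3)C2)cc1` is the untested follow-up to compound 3. The change is diethylcarbamoyl in place of cyclobutylsulfonyl on an aromatic carbon. The rest of the molecule, including the piperidine carboxamide and its isopropyl-oxadiazolyl piperazine, is kept.

For the measured compounds named here, no step between two measured compounds is available, so there is no basis for expecting a move in either direction. The expectation is a step no larger than the scatter, because the whole set shown sits at the limit of > 10000 nM in this assay, at which 3 of the 3 values shown sit, and offers no case where a change at this aromatic carbon produced a number. Compound 4 is estimated at 15000 nM, with a plausible range from 3000 nM to 60000 nM, which means an expected step that the limit leaves unreadable from compound 3 to compound 4.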

Compound 4, half-maximal inhibitory concentration: > 10000 nM
Compound 4 ended at the assay's limit; the forecaster's own chance of this, stated with the estimate: 80%; the middle value does not contradict the limit.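

In this assay compound 4 gives > 10000 nM, which is a limit and not a number. For the compounds shown here, with compound 3 at a limit too, no step from compound 3 to compound 4 can be read, and the whole set stays at one edge: the limit of > 10000 nM in this assay, at which 4 of the 4 values shown sit. The compounds shown leave open how diethylcarbamoyl and cyclobutylsulfonyl compare, and whether any compound of this kind gives a measurable number.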